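This account rests on a few compounds, and the source may have more. Where it says the series, first, only, none or still open, it means among the compounds named here.

Compound 1, `CNS(=O)(=O)c1ccccc1Nc1cc(-c2ccc3ccn(C)c3c2)c2nccnc2c1`: in an assay on lysate for inhibition of 6-phosphofructo-2-kinase/fructose-2,6-bisphosphatase 3 (Homo sapiens), with stated times of 0.5 min and 45 min (on this read-out higher numbers stand for weaker inhibition and lower numbers for stronger inhibition), compound 1 gives > 100000 nM, which is a limit of the assay rather than a number.
Compound 2, `Cn1cc(CNS(=O)(=O)c2ccccc2Nc2cc(-c3ccc4ccn(C)c4c3)c3nccnc3c2)cn1`: in this assay compound 2 gives > 100000 nM, again a limit of the assay.
Compound 3, `Cn1ccc2ccc(-c3cc(Nc4cnccc4C(=O)NCc4cncnc4)cc4nccnc34)cc21`: in this assay compound 3 gives 49500 nM.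

For the measured compounds named here, compound 3 therefore holds the only real number among the three; the two other values only mark where the assay stops. Going by the values given here, the single step between measured compounds, a step that the two limits leave unreadable from compound 1 to compound 2, cannot be sized because both ends sit at the limit of > 100000 nM in this assay, at which 2 of the 3 values shown sit. The step that the piece follows leads to compound 4, `CN1CC(NC(=O)c2ccncc2Nc2cc(-c3ccc4ccn(C)c4c3)c3nccnc3c2)CCC1=O`, which differs from compound 3 in one place: 1-methyl-6-oxopiperidin-3-yl in place of (pyrimidin-5-yl)methyl on an amide-type nitrogen. Among the compounds with values here, no measured pair touches this part of the molecule, and the one measured step gives no readable size, so there is nothing on which to build an expectation of gain or loss. The step from compound 3 to compound 4 is therefore expected to be a 1.0-fold higher number from compound 3 to compound 4 (0.00 log units; within the scatter), that is, nothing beyond the usual scatter. Compound 4 is expected to give about 50000 nM in this assay, with a likely range from 15000 nM to 160000 nM, and a fair chance that only a limit is reported.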

Compound 4, half-maximal inhibitory concentration: 96500 nM
For compound 4 the middle estimate is 1.9-fold (0.29 log units) below the measured one; the measured number falls inside the stated range.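

In this assay, the step of a 1.9-fold higher number from compound 3 to compound 4 (0.29 log units; within the scatter) shows that this place on the amide-type nitrogen can carry two quite different groups and still give values within the usual scatter of each other. An aromatic ring on a methyl link, (pyrimidin-5-yl)methyl, gives way to a non-aromatic ring with a carbonyl, 1-methyl-6-oxopiperidin-3-yl, so on these two compounds the aromatic ring is not needed to keep a readable number. This is the first readable step in the series, since compound 1 and compound 2 give only a limit, and the step between them cannot be read: the limit of > 100000 nM in this assay, at which 2 of the 4 values shown sit.

Neither group tested here separates itself from the other, so the data do not show whether anything at this place can move the number beyond the scatter. An open-chain amine, a carboxylic acid or a longer alkyl chain on the same nitrogen would test that, and the shown compounds also leave open how much of the value comes from this group rather than from the shared core.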